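Acetyl for Methyl on a Flat Cytotoxicity Series

The source may report more compounds than this note shows. Statements on the series, on what has been measured and on what is new or still open speak of the compounds shown alone.

Of the compounds shown here, three sharing one core have been measured in a functional assay on J82 cells (Homo sapiens) for cytotoxicity, read by colorimetric assay and MTT assay; on this read-out higher numbers stand for weaker inhibition and lower numbers for stronger inhibition. Compound 1 `COc1ccc(-c2cc3c(OC)cc(OC)cc3n(C)c2=O)cc1` gives 10000 nM in this assay. Compound 2 `CCN(CC)C(=O)Cn1c(=O)c(-c2ccc(OC)cc2)cc2c(OC)cc(OC)cc21` gives 10000 nM, and compound 3 `COc1ccc(-c2cc3c(OC)cc(OC)cc3n(CCCC#N)c2=O)cc1` gives 10000 nM. The three values sit level with one another: the steps of no change at the digits printed from compound 1 to compound 2 (within the scatter), no change at the digits printed from compound 1 to compound 3 (within the scatter) and no change at the digits printed from compound 2 to compound 3 (within the scatter) all stay within the scatter of repeated measurements, so nothing distinguishes the three compounds on these numbers, and compound 1 stands level with compounds 2 and 3.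

Compound 4 `COc1cc(OC)c2cc(-c3ccc(OC(C)=O)cc3)c(=O)n(C)c2c1` has not yet been measured. It differs from compound 1 by acetyl in place of methyl on an oxygen on an aromatic ring, so the change is an acetyl in place of a methyl on an oxygen on an aromatic ring whose other neighbour is an aromatic carbon. All three measured steps concern a saturated chain carbon bound to an aromatic nitrogen, a different place on the core, so none of them tests this change directly. What they do show is that three changes at one position left the read-out flat. Among the measured compounds shown here, on that basis, and with no closer precedent, compound 4 is expected to show a step of no change at the digits printed from compound 1 to compound 4 (within the scatter), meaning no change beyond the scatter. The estimate for compound 4 is 10000 nM, within a range from 5000 nM to 20000 nM.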

Compound 4, half-maximal inhibitory concentration: 10000 nM
Estimate against measurement, compound 4: no gap at the digits printed; measured number inside the range.
By their numbers in this assay, from the lowest: compounds 1, 2, 3 and 4 (each within the scatter of the next).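

In this assay, among the compounds shown here, replacing methoxy with acetoxy gives no change at the digits printed from compound 1 to compound 4 (within the scatter), the first reading at an oxygen on an aromatic ring, since the earlier steps all concerned a saturated chain carbon bound to an aromatic nitrogen. The flat read-out therefore now extends to a second place on the shared core: acetyl brings 3 heavy atoms where methyl has 1, and adds a double bond and a hydrogen-bond acceptor, yet this larger group leaves compound 4 at 10000 nM in this assay. No measurement is at hand that would explain this lack of change.

All four compounds share the same printed value, so they include no step beyond the scatter and cannot show which changes on this core, if any, would move the number in this assay. As far as these compounds go, whether a hydroxy group or an amine in place of the methoxy, or a carboxylic acid or longer chain on the aromatic nitrogen, would shift the read-out remains open.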